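Amide substituent change on the fluorophenyl series

The source may report more compounds than this note shows. Statements on the series, on what has been measured and on what is new or still open speak of the compounds shown alone.

Measured so far in a functional assay on QGY7701 cells (Homo sapiens) for cytotoxicity, read by MTT assay, with a stated time of 24 h; a higher number here means a weaker inhibitor, a lower number a stronger inhibitor:
compound 1 `C=CC1=C(C(=O)Nc2ccccc2OC)C(c2ccc(F)cc2)OC1`, 52800 nM
compound 2 `C=CC1=C(C(=O)NCc2ccc(C)cc2)C(c2ccc(OC)cc2)OC1`, 43100 nM
compound 3 `C=CC1=C(C(=O)NCc2ccc(C)cc2)C(c2ccc(F)cc2)OC1`, 62100 nM

Compound 3 gives the highest of the three numbers, yet its gaps to compound 1 and compound 2 both lie within the scatter: a 1.2-fold higher number from compound 1 to compound 3 (0.07 log units; within the scatter) and a 1.4-fold higher number from compound 2 to compound 3 (0.16 log units; within the scatter).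

Compound 4 `C=CC1=C(C(=O)NCCCCC)C(c2ccc(F)cc2)OC1` is not yet measured. It differs from compound 3 by butyl in place of 4-methylphenyl on a saturated chain carbon bound to an amide-type nitrogen. Within the data shown here, the one step already made on the amide nitrogen, a 1.2-fold higher number from compound 1 to compound 3 (0.07 log units; within the scatter), stayed within the scatter, so a change of the group on that nitrogen has so far left this assay essentially unmoved. On this basis no step beyond the scatter is expected from compound 3 to compound 4, estimated as a 1.0-fold lower number from compound 3 to compound 4 (0.01 log units; within the scatter). Compound 4 is therefore expected at about 60000 nM, with a range from 25000 nM to 150000 nM.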

Compound 4, half-maximal inhibitory concentration: > 100000 nM
Compound 4 gave a limit, no number (the forecaster's own chance of this, stated with the estimate: 15%); at least 1.6-fold (0.22 log units) between middle value and limit.
By their numbers in this assay, from the lowest: compounds 2, 1 and 3 (each within the scatter of the next). At a limit, above all of these: compound 4.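

Compound 4 gives a limit of the assay, not a number: the limit of > 100000 nM in this assay, at which 1 of the 4 values shown sits.

On an amide-type nitrogen, pentyl gives an at least 1.6-fold higher number from compound 3 to compound 4 (0.20 log units; that floor lies within the scatter) and an at least 1.8-fold higher number from compound 1 to compound 4 (0.27 log units; that floor lies within the scatter) in this assay, so neither floor shows a step beyond the scatter. Pentyl is the only group shown there without a ring, and compound 4 is the only compound at the limit, a single case that sets no pattern.

On these data alone, the true value of compound 4, and so the real size of both steps, stays open. Also open, as far as these compounds go, is whether a propyl chain, or a pentyl chain carrying an amine, on that nitrogen would give a number in this assay.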